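Aminocyclohexenetriols: branching the amine substituent

A few compounds are considered here, and "the series" means these few. Any claim that something is new, unique, unknown or untested is made for them only; others in the source may bear on it.

Measured so far:
compound 1 `CCCCN[C@@H]1C=C[C@H](O)[C@H](O)[C@H]1O`: 50000 nM
compound 2 `CCCCCCCCCCN[C@@H]1C=C[C@H](O)[C@H](O)[C@H]1O`: 43000 nM

The two measured compounds share one core and differ only in the chain on the amine nitrogen. In an assay for inhibition of beta-galactosidase (Homo sapiens), read by fluorescence, with a stated time of 30 min, at pH 4.5 (a lower number here means a stronger inhibitor, a higher number a weaker inhibitor), compound 1 gives 50000 nM, and compound 2 gives 43000 nM; the step of a 1.2-fold lower number from compound 1 to compound 2 (0.07 log units; within the scatter) lies within the scatter, so the two numbers cannot be told apart and compound 1 has no separate standing among them.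

Compound 3 `CCC(CC)N[C@@H]1C=C[C@H](O)[C@H](O)[C@H]1O` is the next case. It carries pentan-3-yl in place of butyl on an amine nitrogen. For the measured compounds named here, the only step that bears on this change is the one from compound 1 to compound 2, where a much longer chain on the same nitrogen produced no movement beyond the scatter. A change in the chain on this nitrogen is therefore expected to leave the number about where compound 1 sits, with no step beyond the scatter: no change at the digits printed from compound 1 to compound 3 (within the scatter).

Compound 3 is expected to give 50000 nM in this assay, within the range 20000 nM to 125000 nM.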

Compound 3, half-maximal inhibitory concentration: > 1000000 nM
Compound 3: no number, only a limit; the forecaster's own chance of this, stated with the estimate: 20%; middle value at least 20-fold (1.30 log units) away from the limit.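

On the amine nitrogen of the shared core, the chain is not indifferent in this assay: pentan-3-yl in place of butyl gives an at least 20-fold higher number from compound 1 to compound 3 (1.30 log units; beyond the scatter). For compound 3, > 1000000 nM is a limit of the assay and not a number: the limit of > 1000000 nM in this assay, at which 1 of the 3 values shown sits. The earlier step, a 1.2-fold lower number from compound 1 to compound 2 (0.07 log units; within the scatter), showed only that a much longer straight chain left the number within the scatter, so this position separates the chains in a way that chain length alone did not reveal.

Pentan-3-yl is the only branched chain among the compounds shown, so one case cannot establish whether branching itself accounts for the step. Isopropyl or cyclohexyl on the same nitrogen would test whether the result extends beyond this one group.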